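The compounds below may be only part of what the source reports. "The series", "measured", "known", "first", "only" and "open" are said of these compounds alone.

In a functional assay on A2780 ADR cells (Homo sapiens) for cytotoxicity, read by MTT assay, with a stated time of 24 h (on this read-out lower numbers stand for stronger inhibition and higher numbers for weaker inhibition), compound 1 `CCCCC[C@@H](C[C@H](O)C[C@@H]1CC=CC(=O)O1)OC` gives 26300 nM, compound 2 `CCCCC[C@H](C[C@@H](O)C[C@H]1CC=CC(=O)O1)OC` gives 18100 nM and compound 3 `CCCCC[C@@H](C[C@@H](O)C[C@@H]1CC=CC(=O)O1)OC` gives 46300 nM. These three differ only in configuration. One gap to compound 3 stays within the scatter, a 1.8-fold higher number from compound 1 to compound 3 (0.25 log units; within the scatter), while the other goes beyond it, a 2.6-fold higher number from compound 2 to compound 3 (0.41 log units; beyond the scatter). Compound 4 `CCCCC[C@@H](C[C@@H](O)C[C@H]1CC=CC(=O)O1)OC` is related to compound 3 by the two compounds have the same atoms and bonds and differ only in configuration as drawn: 1 of 3 stereo elements differ; a stereocentre at a saturated ring carbon is drawn S in compound 3 and R in compound 4. Within the data shown here, no measured pair changes this stereocentre at a saturated ring carbon alone. It changed along with both chain stereocentres in a 1.5-fold lower number from compound 1 to compound 2 (0.16 log units; within the scatter), and along with one chain stereocentre in a 2.6-fold higher number from compound 2 to compound 3 (0.41 log units; beyond the scatter). A small move towards a lower number is therefore expected, probably within the scatter. The expected step is a 1.5-fold lower number from compound 3 to compound 4 (0.19 log units; within the scatter). For compound 4 the estimated value is 30000 nM, with an expected range from 15000 nM to 60000 nM.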

Compound 4, half-maximal inhibitory concentration: 25200 nM
Compound 4: the middle estimate sits 1.2-fold (0.08 log units) above what was measured; the range from low to high includes it.
By their numbers in this assay, from the lowest: compounds 2, 4, 1 and 3 (each within the scatter of the next, the first and the last beyond it).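

Among these compounds, compound 4 gives the first pair in which the stereocentre at a saturated ring carbon changes alone, and in this assay that change gives a 1.8-fold lower number from compound 3 to compound 4 (0.26 log units; within the scatter) as its whole measured effect. Changing one chain stereocentre gives a 1.4-fold higher number from compound 2 to compound 4 (0.14 log units; within the scatter) while changing a chain stereocentre together with the ring stereocentre gives a 1.0-fold lower number from compound 1 to compound 4 (0.02 log units; within the scatter) in the same assay. No single inversion among these four compounds goes beyond the scatter, and only the double change from compound 2 to compound 3 does.

All four compounds share the same atoms and bonds, so these results cannot tell how a longer chain or an amine on the shared core would read in this assay here.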